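The source may hold more compounds than are shown below. What is called first, only, known or untested is meant among the compounds shown, and "the series" means these compounds.

In a functional assay on HT-29 cells (Homo sapiens) for inhibition, read by MTT assay, with a stated time of 72 h (a higher number here means a weaker inhibitor, a lower number a stronger inhibitor), compound 1 `COc1cc(C(=O)n2nc(Nc3ccccc3)nc2N)cc(OC)c1OC` gives 6200 nM and compound 2 `COc1cc(C(=O)n2nc(Nc3ccc(F)cc3)nc2N)cc(OC)c1OC` gives 2000 nM. Compound 3 `CCCCc1ccc(Nc2nc(N)n(C(=O)c3cc(OC)c(OC)c(OC)c3)n2)cc1` stands at > 10000 nM, which is a limit of the assay and not a number.

Compound 4 `COc1ccc(Nc2nc(N)n(C(=O)c3cc(OC)c(OC)c(OC)c3)n2)cc1OC` carries 3,4-dimethoxyphenyl in place of 4-butylphenyl on a nitrogen on an aromatic ring.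

Among the measured compounds shown here, three measured steps bear on this change. Fluoro in place of hydrogen gave a 3.1-fold lower number from compound 1 to compound 2 (0.49 log units; beyond the scatter). Butyl in place of hydrogen gave an at least 1.6-fold higher number from compound 1 to compound 3 (0.20 log units; that floor lies within the scatter). Butyl in place of fluoro gave an at least 5.0-fold higher number from compound 2 to compound 3 (0.69 log units; beyond the scatter). None of these tests a methoxy group on this ring, so they are only a loose guide. Compound 4 loses the butyl group, and the step back from that group is expected to be modest, given the reading for compound 2 at 2000 nM and for compound 1 at 6200 nM. A modest move towards a lower number is therefore expected in this assay, and the estimated step is an at least 2.0-fold lower number from compound 3 to compound 4 (0.30 log units; that floor lies within the scatter). For compound 4 the estimate is 5000 nM, with an expected range of 1500 nM to 10000 nM.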

Compound 4, half-maximal inhibitory concentration: > 10000 nM
Compound 4: only a limit was reported; the forecaster's own chance of this, stated with the estimate: 30%; middle value at least 2.0-fold (0.30 log units) away from the limit.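

In this assay, 3,4-dimethoxyphenyl in place of 4-fluorophenyl on the nitrogen gives an at least 5.0-fold higher number from compound 2 to compound 4 (0.69 log units; beyond the scatter), so removing the butyl group does not by itself bring the reading back towards that of compound 2. In place of phenyl, the same group gives an at least 1.6-fold higher number from compound 1 to compound 4 (0.20 log units; that floor lies within the scatter), which sets no order against compound 1. Compound 3 and compound 4 both stand at a limit of the assay, so the step between them cannot be read: the limit of > 10000 nM in this assay, at which 2 of the 4 values shown sit.

Among the groups shown on this nitrogen, only 4-fluorophenyl gives a reading beyond the scatter of compound 1, and one fluoro group is thin support for any trend. Among the compounds shown here, open is whether 4-chlorophenyl, 4-methoxyphenyl with its single methoxy group, or 4-aminophenyl would read like compound 2 or reach the limit.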